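Series notes: methyl removed from the aromatic ring

The compounds below may be only part of what the source reports. "The series", "measured", "known", "first", "only" and "open" are said of these compounds alone.

Measured compounds:
- compound 1 `Cc1cccc(/C(N)=N/NC(=S)N2CCCCC2)n1`: 39%
- compound 2 `Cc1cccc(/C(N)=N/NC(=S)N2CCCC2)n1`: 38.2%
- compound 3 `N/C(=N\NC(=S)N1CCN(c2ccccn2)CC1)c1ccccn1`: 46.4%

In a functional assay on MCF7 cells (Homo sapiens) for cytotoxicity, read by MTT assay, with a stated time of 72 h, tested at 10 uM (on this read-out higher numbers stand for more inhibition of growth at the one concentration tested and lower numbers for less inhibition of growth), compound 1 gives 39%. Compound 1 stands second highest of the three numbers; its nearest neighbour is compound 2, its furthest compound 3, and both gaps lie within the scatter, so no order among the three can be read from these values. For the measured compounds named here, the one measured step, a number 0.8 percentage points lower from compound 1 to compound 2 (within the scatter), concerns the thiocarbonyl substituent and leaves the number essentially unchanged.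

Compound 4 `N/C(=N\NC(=S)N1CCCCC1)c1ccccn1` is not yet measured. Relative to compound 1 the change is hydrogen in place of methyl on an aromatic carbon. Going by the values given here, no measured step touches this position. Compound 3, which also carries hydrogen there but differs at the thiocarbonyl nitrogen, gives 46.4%, within the scatter of compound 1. Taken together, the step from compound 1 to compound 4 is expected to be a number 3 percentage points higher from compound 1 to compound 4 (within the scatter), with no direction beyond the scatter. The estimate for compound 4 in this assay is therefore 42%, with a range from 28% to 56%.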

Compound 4, percent growth inhibition at one concentration: 53.1%
For compound 4 the middle estimate is 11.1 percentage points below the measured one, within the range that was stated.
By their numbers in this assay, from the lowest: compounds 2, 1, 3 and 4 (each within the scatter of the next, the first and the last beyond it).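

In this assay, for the compounds shown here, this is the first single change to move the number beyond the scatter: on an aromatic carbon next to the ring nitrogen, hydrogen in place of methyl gives a number 14.1 percentage points higher from compound 1 to compound 4 (beyond the scatter) and this modest step contrasts with the thiocarbonyl step, a number 0.8 percentage points lower from compound 1 to compound 2 (within the scatter) in which the number barely moves. The methyl is therefore not required for growth inhibition at the one concentration tested, and with the piperidin-1-yl group kept, the compound without it scores higher. Nothing available accounts for this difference.

From the compounds shown here alone, it remains open whether the same change would raise the number with the pyrrolidin-1-yl group of compound 2 in place. Also open, going by these compounds, is how other groups on this carbon, such as ethyl, methoxy, chlorine or an amine, would compare with hydrogen and methyl.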